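From compound 3 to compound 4: methyl to ethyl

The compounds below may be only part of what the source reports. "The series", "measured", "known", "first", "only" and "open" are said of these compounds alone.

Measured in an ADME assay on H9c2 cells (Rattus norvegicus) for cytotoxicity; a lower number here means a stronger inhibitor, a higher number a weaker inhibitor:
Compound 1 `CCCC(=O)Nc1nc2ccc(Cl)cc2s1`: > 50000 nM
Compound 2 `O=C(Nc1nc2ccc(Cl)cc2s1)C1COC1`: > 50000 nM
Compound 3 `CN(C(=O)C1CC1)c1nc2ccc(Cl)cc2s1`: > 50000 nM

Compound 3 reads > 50000 nM, which is a limit of the assay and not a number. Compound 4 `CCN(C(=O)C1CC1)c1nc2ccc(Cl)cc2s1` has methyl in place of hydrogen on a saturated chain carbon bound to an amide-type nitrogen, so methyl becomes ethyl: methyl in place of hydrogen on a saturated chain carbon bound to an amide-type nitrogen. Among the compounds with values here, the only measured step is a step that the two limits leave unreadable from compound 1 to compound 2, and it offers no size to carry over. The evidence is the limit of > 50000 nM in this assay, at which 3 of the 3 values shown sit. On that evidence, no change beyond the scatter is expected in this assay, and the estimated step is a step that the limit leaves unreadable from compound 3 to compound 4. For compound 4 the expected value is 60000 nM, with an estimated range from 30000 nM to 120000 nM.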

Compound 4, half-maximal inhibitory concentration: > 50000 nM
Compound 4: a limit, no number (the forecaster's own chance of this, stated with the estimate: 85%); the middle value lies beyond the limit too.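

Compound 3 and compound 4 both read as limits and not as numbers in this assay, so no step can be read between them. The compounds shown leave open which structural change, if any, would give a measurable number in this assay.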